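Aryl variation on the triazole in a HepG2 urea series

The source may report more compounds than this note shows. Statements on the series, on what has been measured and on what is new or still open speak of the compounds shown alone.

Compound 1, `N#Cc1cccc(-n2cc(COc3cccc(NC(=O)Nc4ccc(Cl)c(C(F)(F)F)c4)c3)nn2)c1`: 2760 nM
Compound 2, `O=C(Nc1cccc(OCc2cn(-c3cccc(Br)c3)nn2)c1)Nc1ccc(Cl)c(C(F)(F)F)c1`: 1040 nM

In a functional assay on HepG2 cells (Homo sapiens) for inhibition, read by MTT assay, with a stated time of 72 h (on this read-out lower numbers stand for stronger inhibition and higher numbers for weaker inhibition), compound 2 gives 1040 nM, the lowest of the two numbers; compound 1 gives 2760 nM. Within the data shown here, the one measured step, a 2.7-fold lower number from compound 1 to compound 2 (0.42 log units; beyond the scatter), concerns a different position and bears only loosely on what follows. Compound 3, `O=C(Nc1cccc(OCc2cn(-c3ccccc3C(F)(F)F)nn2)c1)Nc1ccc(Cl)c(C(F)(F)F)c1`, differs from compound 2 by 2-(trifluoromethyl)phenyl in place of 3-bromophenyl on an aromatic nitrogen. Among the measured compounds shown here, no measured step shows what such a change does here, so compound 3 is expected to give a number near that of compound 2, with a 1.4-fold higher number from compound 2 to compound 3 (0.16 log units; within the scatter) within the scatter. Compound 3 is therefore estimated at 1500 nM, in the range 500 nM to 4500 nM.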

Compound 3, half-maximal inhibitory concentration: 2320 nM
For compound 3 the middle estimate is 1.5-fold (0.19 log units) below the measured one; the range from low to high includes it.
By their numbers in this assay, from the lowest: compound 2; then compounds 3 and 1 (each within the scatter of the next).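

In this assay, 2-(trifluoromethyl)phenyl does not match 3-bromophenyl on the aromatic nitrogen, with a 2.2-fold higher number from compound 2 to compound 3 (0.35 log units; beyond the scatter) as the step between them. Against 3-cyanophenyl the same group gives a 1.2-fold lower number from compound 1 to compound 3 (0.08 log units; within the scatter) and so is not separated from it. No measurement here accounts for either step.
Compound 3 alters both the substituent and its place on the phenyl ring, so these two changes cannot be told apart. On these data alone, how an amine or a carboxylic acid on that phenyl ring would read remains open.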